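Swapping the pyrrole for an aminothiophene in a chalcone-like chain

This account rests on a few compounds, and the source may have more. Where it says the series, first, only, none or still open, it means among the compounds named here.

Compound 1, `COc1ccc(-c2cc3ccccc3nc2/C=C/C(=O)c2ccc(O)cc2)cc1`, gives 6710 nM.
Compound 2, `COc1ccc(-c2cc3ccccc3nc2/C=C/C(=O)c2ccc[nH]2)cc1`, gives > 10000 nM, which is a limit of the assay.
Compound 3, `COc1ccc(-c2cc3ccccc3nc2/C=C/C(=O)c2sccc2N)cc1`, is not yet measured.

All three compounds share a core in which a quinoline bearing a methoxyphenyl group carries an unsaturated chain ending in a carbonyl; only the group on that carbonyl carbon changes. In a functional assay on MCF7 cells (Homo sapiens) for antiproliferative activity, read by XTT assay, with a stated time of 72 h (on this read-out lower numbers stand for stronger inhibition and higher numbers for weaker inhibition), compound 1 gives 6710 nM. On these data alone, for compound 2 this assay reports only a limit, > 10000 nM, so its true number is unknown beyond that bound. The step of an at least 1.4-fold higher number from compound 1 to compound 2 (0.17 log units; that floor lies within the scatter) is therefore a floor rather than a measured size, and compound 2 sits at the limit of > 10000 nM in this assay, at which 1 of the 2 values shown sits.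

Compound 3 differs from compound 2 by 3-aminothiophen-2-yl in place of 1H-pyrrol-2-yl on a carbonyl carbon. For the measured compounds named here, no measured step covers this particular change; the only step on hand, from compound 1 to compound 2, went toward the limit and can give no direction for the next move. Because compound 2 stands at the limit of > 10000 nM in this assay, at which 1 of the 2 values shown sits, compound 3 is expected to stay near that bound, with a step that the limit leaves unreadable from compound 2 to compound 3 not expected to reach beyond the usual scatter. The estimate for compound 3 is 12000 nM, with a range from 4000 nM to 40000 nM.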

Compound 3, half-maximal inhibitory concentration: > 10000 nM
Compound 3 ended at the assay's limit (the forecaster's own chance of this, stated with the estimate: 60%); the middle value does not contradict the limit.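

In this assay, compound 3 ends at the limit, as compound 2 does, so a second five-membered aromatic ring on this carbonyl carbon, now carrying sulfur and an amino group, also yields no measured number: the limit of > 10000 nM in this assay, at which 2 of the 3 values shown sit.

Putting 3-aminothiophen-2-yl in place of 4-hydroxyphenyl gives an at least 1.4-fold higher number from compound 1 to compound 3 (0.17 log units; that floor lies within the scatter), which is a floor and not a measured size, and it is the same floor seen with 1H-pyrrol-2-yl. Both ends of the step between the two five-membered rings are limits, so that step cannot be read and neither group can be ranked over the other.

On these data alone, compound 1 remains the only one of the three with an actual number, so it stays open how far the other two lie past the limit and whether the 4-hydroxyphenyl group is needed for that measurable value. A plain phenyl or a 4-aminophenyl group on the same carbonyl carbon would test whether a six-membered aromatic ring alone gives a readable number, or whether the hydroxyl on it matters.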